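This account rests on a few compounds, and the source may have more. Where it says the series, first, only, none or still open, it means among the compounds named here.

Measured compounds:
- compound 1, `CCc1nc(N)c2nc(O)n(Cc3ccccc3)c2n1`: in a functional assay (spleen, spleen) for activation, with Mus musculus as the target (a lower number here means that less compound is needed, a higher number that more compound is needed for the effect), compound 1 gives 1 uM
- compound 2, `Nc1ncnc2c1nc(O)n2Cc1ccc(F)cc1`: in this assay compound 2 gives 10 uM
- compound 3, `COc1cccc(Cn2c(O)nc3c(N)ncnc32)c1`: in this assay compound 3 gives 10 uM

Compound 1 stands lowest of the three numbers, so it needs the least compound for the effect. Compound 2 and compound 3 both give higher numbers than compound 1, and each of those gaps lies beyond the usual scatter of repeated measurements.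

The next compound, compound 4, `Nc1nc(N)c2nc(O)n(Cc3ccccc3)c2n1`, is built from compound 1 by one change: amino in place of ethyl on an aromatic carbon. The ethyl group of compound 1 is gone, and an amino group sits at the same place on the core. Going by the values given here, no measured pair in this set shows this exact exchange, so its effect cannot be read from the data directly; only compound 1 itself gives a foothold.

The step from compound 1 to compound 4 in this assay is expected to be a 3.0-fold higher number from compound 1 to compound 4 (0.48 log units; beyond the scatter), a modest rise in the number needed. For compound 4 the estimate in this assay is 3 uM, with a range from 1 uM to 30 uM.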

Compound 4, minimum effective concentration: 10 uM
For compound 4 the middle estimate is 3.3-fold (0.52 log units) below the measured one, and the stated range covers the measured number.
By their numbers in this assay, from the lowest: compound 1; then compounds 2, 3 and 4 (each within the scatter of the next).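

In this assay, putting amino in place of ethyl on the aromatic carbon between two ring nitrogen atoms gives a 10-fold higher number from compound 1 to compound 4 (1.00 log units; beyond the scatter), a step beyond the usual scatter. Going by these compounds alone, the earlier compounds offered no pair differing in one place, so this is the first direct sign that the group at this position affects how much compound is needed. With ethyl there, less compound is needed than with amino, although nothing measured here explains the difference.

Only ethyl and amino can be compared at this position, so two points cannot show how the number follows the choice of group. A methyl group, a longer chain such as butyl, or a methoxy group could each show whether the number falls further or rises again.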